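Swapping One Azole Ring for Another on a Shared Core

A few compounds are considered here, and "the series" means these few. Any claim that something is new, unique, unknown or untested is made for them only; others in the source may bear on it.

Compound 1, `O=C(O)c1cc(-c2cc[nH]n2)ccc1O`: > 250 mg/kg
Compound 2, `O=C(O)c1ccc(-c2cscn2)cc1O`: 70 mg/kg

In a functional assay on the whole organism for inhibition, with Rattus norvegicus as the target, read by paw edema (a higher number here means that more compound is needed for the effect, a lower number that less compound is needed), compound 1 sits at a limit of the assay, (the limit of > 250 mg/kg in this assay, at which 1 of the 2 values shown sits), so no number is known for it. Compound 3, `O=C(O)c1cc(-c2ncc[nH]2)ccc1O`, differs from compound 1 by 1H-imidazol-2-yl in place of 1H-pyrazol-3-yl on an aromatic carbon. Among the measured compounds shown here, no measured step guides this change, so the shift is expected to be small, an at least 1.1-fold lower number from compound 1 to compound 3 (0.05 log units; that floor lies within the scatter), at most near the usual scatter, in no clear direction. Compound 3 is therefore expected around 220 mg/kg, between 90 mg/kg and 500 mg/kg, and this assay may again report only a limit.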

Compound 3, dose for half-maximal effect: 200 mg/kg
Compound 3: middle estimate off by 1.1-fold (0.04 log units), on the high side, within the range that was stated.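

Putting 1H-imidazol-2-yl in place of 1H-pyrazol-3-yl on the shared core gives a measured number in this assay, with compound 3 at 200 mg/kg. For compound 1, > 250 mg/kg is a limit of the assay and not a number. All that can be read is an at least 1.2-fold lower number from compound 1 to compound 3 (0.09 log units; that floor lies within the scatter), a floor and not a true size, and the limit behind it is this one: the limit of > 250 mg/kg in this assay, at which 1 of the 3 values shown sits.

From the compounds shown here alone, whether an amine or a carboxylic acid at this place would move the number beyond the scatter remains open. Compound 2 differs from compound 1 and compound 3 in more than one place, so it does not settle this.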